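Cyclopentylamino to isopropylamino on the shared core

The source may report more compounds than this note shows. Statements on the series, on what has been measured and on what is new or still open speak of the compounds shown alone.

Measured compounds:
- compound 1 `CN1CCN(c2ccc(Nc3ncc(/N=C/c4ccccc4)c(NC4CCCC4)n3)cc2)CC1`: 28600 nM
- compound 2 `NS(=O)(=O)c1ccc(Nc2ncc(/N=C/c3ccccc3)c(NC3CCCC3)n2)cc1`: 27000 nM

In a functional assay on HT-29 cells (Homo sapiens) for antiproliferative activity, read by MTT assay (on this read-out higher numbers stand for weaker inhibition and lower numbers for stronger inhibition), compound 1 gives 28600 nM and stands at the highest of the two numbers recorded, with compound 2 nearest. For the measured compounds named here, the only measured step, a 1.1-fold lower number from compound 1 to compound 2 (0.03 log units; within the scatter), concerns a different part of the molecule; the two values lie within the scatter of each other, so neither compound is distinguished from the other on this read-out.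

Compound 3 `CC(C)Nc1nc(Nc2ccc(N3CCN(C)CC3)cc2)ncc1/N=C/c1ccccc1` is not yet measured. It differs from compound 1 by isopropyl in place of cyclopentyl on a nitrogen on an aromatic ring. Going by the values given here, no measured pair touches this nitrogen, so nothing measured bears directly on the step. The step from compound 1 to compound 2 shows only that a distant replacement left the number unchanged; it gives no guide to the size of a change at the amine.

Among the compounds with values here, with no relevant precedent, the expectation for compound 3 is a number close to that of compound 1, with a step of a 1.2-fold higher number from compound 1 to compound 3 (0.06 log units; within the scatter) not beyond the scatter. The estimate for compound 3 is 33000 nM, with a range from 12000 nM to 100000 nM.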

Compound 3, half-maximal inhibitory concentration: 12100 nM
Estimate against measurement, compound 3: 2.7-fold (0.44 log units) above; low and high end bracket the measured number.
By their numbers in this assay, from the lowest: compound 3; then compounds 2 and 1 (each within the scatter of the next).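

In this assay, for the compounds shown here, the nitrogen on an aromatic ring is the first place where a change moves the number beyond the scatter: isopropyl in place of cyclopentyl gives a 2.4-fold lower number from compound 1 to compound 3 (0.37 log units; beyond the scatter), a modest step, whereas the only earlier step, a 1.1-fold lower number from compound 1 to compound 2 (0.03 log units; within the scatter), stayed within it. The five-membered ring of the cyclopentyl group is therefore not needed to hold the number at the level of compound 1, and the open-chain isopropyl group goes with stronger inhibition on this read-out, though this rests on one pair that carries 4-methylpiperazin-1-yl. Nothing at hand accounts for the size or direction of this step.

Still open, going by these compounds, is whether the number keeps falling with a smaller group on this nitrogen, such as ethyl or methyl, or rises again with a larger ring such as cyclohexyl. Also open, on these data alone, is whether the change from cyclopentylamino to isopropylamino gives a step of similar size on the sulfamoyl compound 2, so the effect at this nitrogen cannot yet be taken as independent of the distant group.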